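Swapping the aryl group on the thiazolidinone nitrogen

The source may report more compounds than this note shows. Statements on the series, on what has been measured and on what is new or still open speak of the compounds shown alone.

Among the measured compounds shown here, compound 2 `COc1cccc(OC)c1N1C(=O)CSC1c1cccc(C(=O)NCCCCc2ccccc2)c1` gives 80% in a functional assay on MG-63 cells (Homo sapiens) for inhibition, read by CCK-8 assay, with a stated time of 72 h, tested at 1 uM (on this read-out higher numbers stand for more inhibition at the one concentration tested (going by the name of the read-out) and lower numbers for less inhibition), the lowest of the two numbers known here; compound 1 `COc1ccc(C)cc1N1C(=O)CSC1c1cccc(C(=O)NCCCCc2ccccc2)c1` gives 92%. Compound 3 `COc1c(F)cccc1N1C(=O)CSC1c1cccc(C(=O)NCCCCc2ccccc2)c1` differs from compound 2 by 3-fluoro-2-methoxyphenyl in place of 2,6-dimethoxyphenyl on an amide-type nitrogen in a ring. For the measured compounds named here, the one step available, a number 12 percentage points lower from compound 1 to compound 2 (beyond the scatter), shows that changing the aryl group on the amide-type nitrogen in the ring shifts inhibition modestly. Replacing 2,6-dimethoxyphenyl with a group closer in size to that of compound 1 is therefore expected to raise inhibition by a number 6 percentage points higher from compound 2 to compound 3 (within the scatter). Compound 3 is estimated at 86%, within 72% to 96%.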

Compound 3, a percentage reported as inhibition, at one concentration (the size of the read-out at that concentration, not a potency): 0%
Compound 3: the middle estimate sits 86 percentage points above what was measured; the whole stated range lies above it.
By their numbers in this assay, from the lowest: compound 3; then compound 2; then compound 1.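

On the amide-type nitrogen in the ring, the aryl group can decide between clear inhibition and none: this assay shows a number 80 percentage points lower from compound 2 to compound 3 (beyond the scatter) and a number 92 percentage points lower from compound 1 to compound 3 (beyond the scatter), both large where the earlier step was modest. All three aryl groups carry a methoxy, so a methoxy alone does not keep inhibition here. Nothing available explains the loss. Going by these compounds, it remains open whether the fluorine itself matters, and whether a chlorine in its place would restore inhibition.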